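The source may report more compounds than this note shows. Statements on the series, on what has been measured and on what is new or still open speak of the compounds shown alone.

Measured in an ADME assay on Vero cells (Chlorocebus sabaeus) for cytotoxicity, read by crystal violet staining; on this read-out lower numbers stand for higher toxicity in this test and higher numbers for lower toxicity in this test:
- Compound 1 `Clc1cccc(/N=N/N2CCCC2)c1`: >= 100000 nM
- Compound 2 `COc1ccc(/N=N/N2CCCC2)cc1`: 90000 nM
- Compound 3 `c1ccc(/N=N/N2CCN(c3ncccn3)CC2)cc1`: 65000 nM

The entry for compound 1, >= 100000 nM, is a limit of this assay and not a number. Compound 4 `O=[N+]([O-])c1cccc(/N=N/N2CCCC2)c1` has nitro in place of chloro on an aromatic carbon, meta to a group of 7 heavy atoms: nitro in place of chloro on an aromatic carbon. Within the data shown here, no pair of measured compounds shows this change, so its size cannot be read directly. Compound 2 gives 90000 nM and compound 3 gives 65000 nM, so a modest move towards lower numbers is expected, though none beyond the scatter remains possible. The expected change is an at least 1.5-fold lower number from compound 1 to compound 4 (0.18 log units; that floor lies within the scatter). Compound 4 is estimated at 65000 nM, with an expected range of 25000 nM to 100000 nM.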

Compound 4, half-maximal cytotoxic concentration: 80000 nM
Estimate against measurement, compound 4: 1.2-fold (0.09 log units) below, and the stated range covers the measured number.
By their numbers in this assay, from the lowest: compounds 3, 4 and 2 (each within the scatter of the next). At a limit, above all of these: compound 1.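

In this assay, nitro in place of chloro on an aromatic carbon, meta to a group of 7 heavy atoms, gives an at least 1.2-fold lower number from compound 1 to compound 4 (0.09 log units; that floor lies within the scatter). Among these compounds, this is the first reading of a change at this position, and compound 4 gives 80000 nM, a number rather than a limit. The true size of the step cannot be read, because the entry for compound 1 is a limit of the assay: the limit of >= 100000 nM in this assay, at which 1 of the 4 values shown sits.

From the compounds shown here alone, whether an amine or a carboxylic acid on this aromatic carbon would give a number or reach the limit stays open. So does whether a longer chain in place of chloro would leave the read-out within the scatter of compound 4.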